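A few compounds are considered here, and "the series" means these few. Any claim that something is new, unique, unknown or untested is made for them only; others in the source may bear on it.

In an ADME assay on liver (Mesocricetus auratus) for metabolic stability, using microsomes (a higher number here means faster removal of the compound, a lower number slower removal), compound 1 `O=C(Nc1cc(-c2ccccn2)n[nH]1)N1CCC(c2ccc(F)cc2)CC1` gives 272 mL.min-1.g-1. Compound 2 `O=C(NCc1cccc(Cl)c1)Nc1cc(-c2ccccn2)n[nH]1` gives 434 mL.min-1.g-1, which lies within the scatter of the value for compound 1, so the two cannot be told apart. Compound 3 `O=C(NCc1ccccc1)Nc1[nH]nc(-c2ccccn2)c1C1CC1` is reported only as a limit, > 400 mL.min-1.g-1. Compound 4 `O=C(Nc1cc(-c2ccccn2)n[nH]1)N1CCC(c2ccccc2)CC1` differs from compound 1 in one place: hydrogen in place of fluoro on an aromatic carbon, with hydrogen in place of fluoro on an aromatic carbon, para to a large group. For the measured compounds named here, no measured pair of compounds shows this change, so no step beyond the scatter is expected in this assay. The estimated step of a 1.2-fold higher number from compound 1 to compound 4 (0.07 log units; within the scatter) therefore stays small. Compound 4 is expected at 320 mL.min-1.g-1, with an estimated range of 170 mL.min-1.g-1 to 600 mL.min-1.g-1.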

Compound 4, intrinsic clearance in microsomes: 216 mL.min-1.g-1
Estimate against measurement, compound 4: 1.5-fold (0.17 log units) above; the range from low to high includes it.
By their numbers in this assay, from the lowest: compounds 4, 1 and 2 (each within the scatter of the next).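

The change from 4-fluorophenyl to phenyl now has a measured pair, and in this assay it gives a 1.3-fold lower number from compound 1 to compound 4 (0.10 log units; within the scatter) and so cannot be told from repeat-measurement noise. At this place on the ring, para to a large group, fluoro and hydrogen therefore give numbers that cannot be separated. Nothing measured here offers a reason for this result. Still open, on these data alone, is whether a methoxy group, a nitrile or an amine at this same place would give a step beyond the scatter. Also open, as far as these compounds go, is whether the same change would stay this small on a different ring position.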